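Swapping a Methoxyphenyl for a Cyanophenyl Tail

The source may report more compounds than this note shows. Statements on the series, on what has been measured and on what is new or still open speak of the compounds shown alone.

Measured so far:
compound 1 `Cc1cccc(-c2ccc(COCCCCCN3C[C@H](O)[C@@H](O)[C@H](O)[C@H]3CO)cc2)c1`: 2 nM
compound 2 `COc1cccc(-c2ccc(COCCCCCN3C[C@H](O)[C@@H](O)[C@H](O)[C@H]3CO)cc2)c1`: 20 nM
compound 3 `COc1ccccc1-c1ccc(COCCCCCN2C[C@H](O)[C@@H](O)[C@H](O)[C@H]2CO)cc1`: 3 nM

All three compounds share one core and differ only in the aryl group at the far end of the tail. In an assay on isolated protein for inhibition of Beta-glucosidase (Homo sapiens) (on this read-out higher numbers stand for weaker inhibition and lower numbers for stronger inhibition), compound 3 stands second highest of the three numbers: its nearest neighbour is compound 1 (a 1.5-fold higher number from compound 1 to compound 3 (0.18 log units; within the scatter)), its furthest is compound 2 (a 6.7-fold lower number from compound 2 to compound 3 (0.82 log units; beyond the scatter)). The step of a 10-fold higher number from compound 1 to compound 2 (1.00 log units; beyond the scatter) shows that a small change on this ring can move the number noticeably.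

Compound 4 `N#Cc1ccc(-c2ccc(COCCCCCN3C[C@H](O)[C@@H](O)[C@H](O)[C@H]3CO)cc2)cc1` has not yet been measured. It differs from compound 3 by 4-cyanophenyl in place of 2-methoxyphenyl on an aromatic carbon. Among the measured compounds shown here, no measured step involves a cyano group, so none bears directly on this change; the three steps only show that variation on this ring has moved the number by no more than the step of a 10-fold higher number from compound 1 to compound 2 (1.00 log units; beyond the scatter). The expected step is therefore modest, a 2.7-fold higher number from compound 3 to compound 4 (0.43 log units; beyond the scatter), toward a somewhat higher number. Compound 4 is estimated at 8 nM in this assay, with a range from 2 nM to 40 nM.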

Compound 4, half-maximal inhibitory concentration: 3 nM
Beside the measured number, compound 4's estimate is 2.7-fold (0.43 log units) above it; the measured number falls inside the stated range.
By their numbers in this assay, from the lowest: compounds 1, 3 and 4 (each within the scatter of the next); then compound 2.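

In this assay, the nitrile-bearing ring fits with the low-number compounds: 4-cyanophenyl in place of 2-methoxyphenyl gives no change at the digits printed from compound 3 to compound 4 (within the scatter) and in place of 3-methylphenyl gives a 1.5-fold higher number from compound 1 to compound 4 (0.18 log units; within the scatter) as well. The earlier compounds shown here left it unclear how much a new kind of group on this ring would matter, and here three different aryl groups sit within the scatter of one another, with compound 2 the one going against that pattern at a 6.7-fold lower number from compound 2 to compound 4 (0.82 log units; beyond the scatter) and so still the only one set apart. No measurement available here explains why these aryl groups match or why compound 2 stands apart.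

On these data alone, it remains open whether a ring carrying an amine or a carboxylic acid would stay with compounds 1, 3 and 4. A longer chain in the tail is equally untested in the compounds shown.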